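The source may hold more compounds than are shown below. What is called first, only, known or untested is meant among the compounds shown, and "the series" means these compounds.

Measured so far:
compound 1 `CN1CCN(c2ccc(Nc3ncc4nc(Nc5ccc(F)cc5)n([C@H]5CCCNC5)c4n3)cc2)CC1` — 38 nM
compound 2 `CN1CCN(c2ccc(Nc3ncc4nc(Nc5ccccc5)n([C@H]5CCNC5)c4n3)cc2)CC1` — 530 nM

In a functional assay on HCC827 cells (Homo sapiens) for antiproliferative activity, read by MTT assay, with a stated time of 72 h (on this read-out lower numbers stand for stronger inhibition and higher numbers for weaker inhibition), compound 1 gives 38 nM, the lower of the two numbers; compound 2 gives 530 nM, a gap beyond the usual scatter. Compound 3 `CN1CCN(c2ccc(Nc3ncc4nc(Nc5ccc(F)cc5)n([C@H]5CCN(C(=O)OC(C)(C)C)C5)c4n3)cc2)CC1` is not yet measured. It differs from compound 1 by 1-(tert-butoxycarbonyl)pyrrolidin-3-yl in place of piperidin-3-yl on an aromatic nitrogen. Going by the values given here, no single-change step between measured compounds is known here, so the expectation rests on the values of compound 1 and compound 2 alone. Compound 3 is expected to give a clearly higher number than compound 1, a step of a 39-fold higher number from compound 1 to compound 3 (1.60 log units; beyond the scatter). The estimated value of compound 3 in this assay is 1500 nM, within 300 nM to 8000 nM.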

Compound 3, half-maximal inhibitory concentration: 580 nM
For compound 3 the middle estimate is 2.6-fold (0.41 log units) above the measured one; the measured number falls inside the stated range.
By their numbers in this assay, from the lowest: compound 1; then compounds 2 and 3 (each within the scatter of the next).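

Placing 1-(tert-butoxycarbonyl)pyrrolidin-3-yl instead of piperidin-3-yl on the aromatic nitrogen gives, in this assay, a 15-fold higher number from compound 1 to compound 3 (1.18 log units; beyond the scatter), so activity at this position depends strongly on the group placed there. This one swap changes two things: a six-membered ring becomes a five-membered ring, and the ring nitrogen gains a tert-butoxycarbonyl group and loses its hydrogen-bond donor. No available data explain this loss.

On these data alone, how 1-(tert-butoxycarbonyl)piperidin-3-yl or unsubstituted pyrrolidin-3-yl would behave on the core of compound 1 remains open, so the two changes cannot yet be separated.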